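Trimming the Alkyl Chain of Compound 1

A few compounds are considered here, and "the series" means these few. Any claim that something is new, unique, unknown or untested is made for them only; others in the source may bear on it.

Compound 1 `CCCCCCCCCCc1cc2cn(COCCO)c(O)nc-2n1` is the starting point, and the question is how much of it cells tolerate in a functional assay on HEL cells (Homo sapiens), read by microscopy; a higher number here means that more compound is tolerated, a lower number that less compound is tolerated. Compound 1 gives 80000 nM, the lowest of the two numbers measured. The nearest measured neighbour, compound 3 `CCCCCCCCCCc1cc2cn(COCCO)c(=O)nc2o1`, gives 400000 nM, a gap that lies beyond the usual scatter. Compound 2 `CCCCCc1cc2cn(COCCO)c(=O)nc2o1` reaches only a limit of the assay, > 400000 nM, so no number is known for it.

Compound 4 `CCCCCCc1cc2cn(COCCO)c(O)nc-2n1` differs from compound 1 in one place: hydrogen in place of butyl on a saturated chain carbon, six bonds along the chain from an aromatic carbon. Among the compounds with values here, the only measured step that touches a comparable change sits on the core shared by compounds 2 and 3 and runs the opposite way, adding carbon to the chain: a number no higher from compound 2 to compound 3 (the limit leaves the size open). Going by these compounds, that step rests on (the limit of > 400000 nM in this assay, at which 1 of the 3 values shown sits), so its size stays open, but it shows that the shorter chain on that core was tolerated at least as well as the longer one. Carried over to the present step, which removes carbon from the chain of compound 1, the expectation is a tolerated concentration no lower than that of compound 1 and probably somewhat higher.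

Compound 4 is therefore expected to give about 200000 nM, within a range from 60000 nM to 600000 nM. That estimate means an expected step of a 2.5-fold higher number from compound 1 to compound 4 (0.40 log units; beyond the scatter), with a real chance that the assay again reports only a limit.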

Compound 4, minimum cytotoxic concentration: > 400000 nM
Compound 4: only a limit was reported; the forecaster's own chance of this, stated with the estimate: 30%; at least 2.0-fold (0.30 log units) between middle value and limit.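

In this assay compound 4 gives only a limit of the assay, > 400000 nM. With hydrogen in place of butyl at this position on the chain, the core of compound 1 shows an at least 5.0-fold higher number from compound 1 to compound 4 (0.69 log units; beyond the scatter), so the shorter chain on this core is tolerated better by a margin that can be read as a lower bound, whereas the earlier step on the other core gave no readable size. The upper end of this step stays open, and the limit now marks the shorter-chain member on both cores: the limit of > 400000 nM in this assay, at which 2 of the 4 values shown sit.

The compounds shown leave open how the value moves along the chain on the core of compound 4, which an octyl chain there would begin to show, and whether a still shorter propyl chain would stay at the same limit. They also leave open whether a chain ending in a carboxylic acid or an amine, in place of the plain alkyl chain, would be tolerated as well as the hexyl chain of compound 4.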